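A few compounds are considered here, and "the series" means these few. Any claim that something is new, unique, unknown or untested is made for them only; others in the source may bear on it.

Values in a toxicity assay on GES1 cells (Homo sapiens) for inhibition, read by MTT assay, with a stated time of 72 h; a lower number here means a stronger inhibitor, a higher number a weaker inhibitor:
- compound 1 `Cc1cc(N2CC[C@@H](C)[C@@H](N(C)c3ncnc4[nH]ccc34)C2)n2ncnc2n1`: 57900 nM
- compound 2 `Cc1cc(N2CC[C@@H](C)[C@@H](N(C)c3ncnc4[nH]ccc34)C2)n2nc(SCC3CC3)nc2n1`: 27900 nM
- compound 3 `Cc1ccc(CSc2nc3nc(C)cc(N4CC[C@@H](C)[C@@H](N(C)c5ncnc6[nH]ccc56)C4)n3n2)cc1`: 82500 nM

Compound 3 sits at the high end of these numbers, but its nearest gap lies within the scatter: a 1.4-fold higher number from compound 1 to compound 3 (0.15 log units; within the scatter). Its widest gap goes beyond the scatter: a 3.0-fold higher number from compound 2 to compound 3 (0.47 log units; beyond the scatter).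

The next compound is compound 4 `COc1ccc(CSc2nc3nc(C)cc(N4CC[C@@H](C)[C@@H](N(C)c5ncnc6[nH]ccc56)C4)n3n2)cc1`, with methoxy in place of methyl on an aromatic carbon, para to a large group: methoxy in place of methyl on an aromatic carbon. Going by the values given here, no measured step makes this exchange, so the evidence is indirect. Among the compounds with values here, only the steps at the sulfanyl substituent bear on it. Introducing the entire (4-methylbenzyl)sulfanyl group stays within the scatter: a 1.4-fold higher number from compound 1 to compound 3 (0.15 log units; within the scatter). Introducing the (cyclopropylmethyl)sulfanyl group is a modest step: a 2.1-fold lower number from compound 1 to compound 2 (0.32 log units; beyond the scatter). Exchanging cyclopropyl for 4-methylphenyl on that chain is the biggest step seen in the set, and it is also modest: a 3.0-fold higher number from compound 2 to compound 3 (0.47 log units; beyond the scatter).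

The exchange in compound 4 touches only the end of the 4-methylphenyl group, so no step beyond the scatter is expected, and no direction can be argued from these three compounds. The expected step is small: a 1.2-fold lower number from compound 3 to compound 4 (0.07 log units; within the scatter). In this assay, compound 4 is estimated at 70000 nM, with an expected range from 35000 nM to 130000 nM.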

Compound 4, half-maximal inhibitory concentration: > 100000 nM
Compound 4 was reported as a limit (the forecaster's own chance of this, stated with the estimate: 15%); middle value at least 1.4-fold (0.15 log units) away from the limit.
By their numbers in this assay, from the lowest: compound 2; then compounds 1 and 3 (each within the scatter of the next). At a limit, above all of these: compound 4.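

In this assay compound 4 is reported only as a limit, so every step to it is a floor: the limit of > 100000 nM in this assay, at which 1 of the 4 values shown sits. Methoxy in place of methyl on the aromatic carbon para to a large group gives an at least 1.2-fold higher number from compound 3 to compound 4 (0.08 log units; that floor lies within the scatter), and that floor does not separate compound 4 from compound 3, so no effect of this exchange can be claimed in either direction. What is new lies in the comparison with the smaller groups: the exchange on the chain gives an at least 3.5-fold higher number from compound 2 to compound 4 (0.55 log units; beyond the scatter), showing that the 4-methoxybenzyl compound, like the 4-methylbenzyl compound 3, stands apart from compound 2, whereas adding the whole group to the unsubstituted compound gives an at least 1.7-fold higher number from compound 1 to compound 4 (0.23 log units; that floor lies within the scatter), which leaves compound 4 unresolved from compound 1.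

Open, going by these compounds, is whether an amine or a carboxylic acid in place of methoxy at this position would bring the value back from the limit into a readable range. Also open, on these data alone, is how a longer alkyl chain on the sulfur, in place of cyclopropylmethyl, would stand relative to compound 2.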